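The source may report more compounds than this note shows. Statements on the series, on what has been measured and on what is new or still open speak of the compounds shown alone.

Measured in an ADME assay on HEK293 cells (Homo sapiens) for cytotoxicity, read by ATP content, with a stated time of 6 h (a higher number here means that more compound is tolerated, a lower number that less compound is tolerated), where every value is a limit and not a number:
- Compound 1 `CCCCNc1nc(N)nc2ccn(CC=C(C)C)c12` gives the limit > 24000 nM here
- Compound 2 `CCCCNc1nc(N)nc2ccn(Cc3ccccn3)c12` gives the limit > 24000 nM here
- Compound 3 `CCCCNc1nc(N)nc2ccn(Cc3ncccc3OC)c12` gives the limit > 24000 nM here

Compound 2 stands at the limit of > 24000 nM in this assay, at which 3 of the 3 values shown sit, alongside compound 1 and compound 3, so no order among the three can be read. Compound 4 `CC(Nc1nc(N)nc2ccn(Cc3ccccn3)c12)c1ccccn1` keeps the rest of compound 2 and changes one group: 1-(pyridin-2-yl)ethyl in place of butyl on a nitrogen on an aromatic ring ( 1-(pyridin-2-yl)ethyl in place of butyl on a nitrogen on an aromatic ring ). The nearest measured changes are a step that the two limits leave unreadable from compound 1 to compound 2 and a step that the two limits leave unreadable from compound 2 to compound 3 and also a step that the two limits leave unreadable from compound 1 to compound 3, and none of them replaces the butyl. They give no size to carry over, but all three compounds stayed at the limit. In this assay no step beyond the scatter is therefore expected, in either direction, and another limit is the likeliest report. The expected outcome is a number no higher from compound 2 to compound 4 (the limit leaves the size open) in this case. Compound 4 is estimated at 24000 nM as a rough expected value. The expected range runs from 12000 nM to 48000 nM for this estimate.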

Compound 4, half-maximal cytotoxic concentration: > 24000 nM
Compound 4 was reported as a limit; the forecaster's own chance of this, stated with the estimate: 85%; the middle value sits exactly at the limit.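

Compound 2 and compound 4 are both reported only as limits in this assay, so no step between them can be read, and the same holds for the other compounds shown: the limit of > 24000 nM in this assay, at which 4 of the 4 values shown sit.

The compounds shown leave open the concentration at which any of them becomes cytotoxic, and whether 1-(pyridin-2-yl)ethyl in place of butyl alters it.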